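This account rests on a few compounds, and the source may have more. Where it says the series, first, only, none or still open, it means among the compounds named here.

The measured compounds: compound 1 `COc1ccc(CNc2cc(OC)c(OC)c(OC)c2)cc1C` gives 60900 nM in a functional assay on HCT-116 cells (Homo sapiens) for inhibition, read by MTT assay, with a stated time of 48 h; on this read-out lower numbers stand for stronger inhibition and higher numbers for weaker inhibition; compound 2 `C/C=C/C=C/C(=O)N(Cc1ccc(OC)c(O)c1)c1cc(OC)c(OC)c(OC)c1` gives 180 nM; compound 3 `COc1ccc(CNc2cc(OC)c(OC)c(OC)c2)cc1F` gives 32200 nM.

Compound 2 stands lowest of the three; compound 3 is nearest and compound 1 furthest, both gaps beyond the scatter. Compound 4 `COc1ccc(CN(C(=O)/C=C/CBr)c2cc(OC)c(OC)c(OC)c2)cc1O` differs from compound 2 by bromomethyl in place of prop-1-en-1-yl on a double-bonded chain carbon bound to a double-bonded chain carbon. Among the measured compounds shown here, the only measured step, a 1.9-fold lower number from compound 1 to compound 3 (0.28 log units; within the scatter), concerns an aromatic carbon of two compounds that carry no acyl chain at all, so it does not bear on this change. For the measured compounds named here, no measured step informs the swap on the chain, and compound 4 is therefore expected to stay near compound 2: the estimate is 200 nM, with a range from 50 nM to 1000 nM, and the expected step is a 1.1-fold higher number from compound 2 to compound 4 (0.05 log units; within the scatter).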

Compound 4, half-maximal inhibitory concentration: 59 nM
Estimate against measurement, compound 4: 3.4-fold (0.53 log units) above; the measured number falls inside the stated range.
By their numbers in this assay, from the lowest: compound 4; then compound 2; then compounds 3 and 1 (each within the scatter of the next).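

In this assay, the acyl chain proves open to change: bromomethyl in place of prop-1-en-1-yl on a double-bonded chain carbon bound to a double-bonded chain carbon gives a 3.1-fold lower number from compound 2 to compound 4 (0.48 log units; beyond the scatter) and so a modest gain. Among the compounds shown here, this is the first measured step on the chain, and replacing penta-1,3-dien-1-yl with 3-bromoprop-1-en-1-yl does not cost activity. Nothing measured here explains the step.

Compound 4 brings in bromine and shortens the chain in a single change, and the compounds shown do not separate the two. From the compounds shown here alone, how a chloromethyl group or a plain methyl group would read at this place remains open.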